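The source may report more compounds than this note shows. Statements on the series, on what has been measured and on what is new or still open speak of the compounds shown alone.

Compound 1 `O=C(Nc1cc(C(F)(F)F)cc(C(F)(F)F)c1)c1cccc(F)c1O` gives in an assay on cells for antagonist activity at P2X purinoceptor 2 (Homo sapiens), read by fluorescence and calcium flux, with a stated time of 30 min (a lower number here means a stronger inhibitor, a higher number a weaker inhibitor), a limit of the assay, > 10000 nM.
Compound 2 `O=C(Nc1cc(C(F)(F)F)cc(C(F)(F)F)c1)c1ccc2ccccc2c1O` gives in this assay a limit of the assay, > 10000 nM.
Compound 3 `O=C(Nc1cccc(C(F)(F)F)c1)c1cc(Cl)ccc1O` gives in this assay a limit of the assay, > 10000 nM.

Compound 3 therefore stands nowhere in particular among the measured compounds: its value is only a limit, and no number places it above or below compound 1 or compound 2. For the measured compounds named here, all three values shown sit at the same limit, (the limit of > 10000 nM in this assay, at which 3 of the 3 values shown sit), so the set offers no measured step at all and no ordering among its members.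

The unmeasured compound 4 `O=C(Nc1cc([N+](=O)[O-])cc(C(F)(F)F)c1)c1cc(Cl)ccc1O` is reached from compound 3 by a single change: nitro in place of hydrogen on an aromatic carbon. Going by the values given here, with no measured step to lean on, the expectation for this change rests only on the three limits. A step of the usual scatter in this assay from compound 3 to compound 4 is expected, in no particular direction, estimated as a step that the limit leaves unreadable from compound 3 to compound 4. Compound 4 is accordingly expected to give about 15000 nM in this assay, within a range from 3000 nM to 60000 nM, most likely reported again only as a limit.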

Compound 4, half-maximal inhibitory concentration: > 10000 nM
Compound 4 gave a limit, no number (the forecaster's own chance of this, stated with the estimate: 80%); the middle value does not contradict the limit.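

Compound 3 and compound 4 both give only a limit in this assay, so the change of hydrogen to nitro yields no readable step: the limit of > 10000 nM in this assay, at which 4 of the 4 values shown sit.

The compounds shown leave open how any single change among them shifts the half-maximal inhibitory concentration, and what numerical value any of them would have.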